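Benzamide series: swapping the aryl group on sulfur

The source may report more compounds than this note shows. Statements on the series, on what has been measured and on what is new or still open speak of the compounds shown alone.

Compound 1 `Nc1ccccc1NC(=O)/C=C/c1ccc(CSc2cccc(F)c2)cc1` in a functional assay on HCT-116 cells (Homo sapiens) for inhibition, read by CCK-8 assay, with a stated time of 72 h, tested at 2 uM (on this read-out lower numbers stand for less inhibition of growth and higher numbers for more inhibition of growth at the one concentration tested), gives 7.95%. Compound 3 `Cc1ccc(SCc2ccc(/C=C/C(=O)Nc3ccccc3N)cc2)cc1` carries 4-methylphenyl in place of 3-fluorophenyl on a sulfur; in this assay compound 3 gives 6.23%, so that a number 1.7 percentage points lower from compound 1 to compound 3 (within the scatter). Compound 2 `Nc1ccccc1NC(=O)c1ccc(CSc2cccc(F)c2)cc1` differs from compound 1 in the core; the difference between the two cores is not broken down here. In this assay compound 2 gives 5.5%. Compound 4 `Cc1ccc(SCc2ccc(C(=O)Nc3ccccc3N)cc2)cc1`, not yet measured, carries 4-methylphenyl in place of 3-fluorophenyl on a sulfur relative to compound 2; the place reads word for word as in the pair of compound 1 and compound 3, so this is the same change. On that basis the expected step is a number 1 percentage points lower from compound 2 to compound 4 (within the scatter), resting on the measured step of a number 1.7 percentage points lower from compound 1 to compound 3 (within the scatter). The expected number for compound 4 in this assay is 4.5%. For compound 4 the estimated range runs from -4% to 14%.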

Compound 4, percent growth inhibition at one concentration: 74.8%
For compound 4 the middle estimate is 70.3 percentage points below the measured one; measured number above the stated range.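

In this assay, 4-methylphenyl in place of 3-fluorophenyl on a sulfur does not carry over from one core to the other, and on the core of compound 2 the step is a number 69.3 percentage points higher from compound 2 to compound 4 (beyond the scatter). The two steps differ: the same change on two cores in this assay, a number 1.7 percentage points lower (within the scatter) from compound 1 to compound 3 and a number 69.3 percentage points higher (beyond the scatter) from compound 2 to compound 4, 71 percentage points apart, beyond the scatter of two such steps. On these two pairs the outcome of the change depends on the core, but the pairs do not show why, and they give no rule for any further core.

Open, going by these compounds, is how a plain phenyl on the sulfur would read on either core. Also open, on these data alone, is whether the same gap between cores appears with an amine or a carboxylic acid in place of the aryl group.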